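A few compounds are considered here, and "the series" means these few. Any claim that something is new, unique, unknown or untested is made for them only; others in the source may bear on it.

Measured so far in an assay on CHO cells for displacement of a labelled ligand from prostaglandin E2 receptor EP3 subtype (Mus musculus), read by scintillation counting, with a stated time of 60 min; on this read-out higher numbers stand for weaker inhibition and lower numbers for stronger inhibition: compound 1 `O=C(O)CCCSCCN1C(=O)OC[C@@H]1/C=C/[C@@H](O)Cc1cccc(C(F)(F)F)c1` gives 1600 nM; compound 2 `O=C(O)CCCSCCN1C(=O)SC[C@@H]1/C=C/[C@@H](O)Cc1cccc(C(F)(F)F)c1` gives 280 nM.

Compound 1 holds the highest of the two numbers in this assay ; the nearest value, that of compound 2, is lower by a margin beyond the scatter. Compound 3 `O=C(O)CCCSCCN1C(=O)OC[C@@H]1/C=C/[C@@H](O)Cc1cccc(Cl)c1` differs from compound 1 by chloro in place of trifluoromethyl on an aromatic carbon. Within the data shown here, no measured pair shows this change, so its size is unknown; a small shift toward a higher number, or none beyond the scatter, is expected. For compound 3 the estimate in this assay is 2500 nM, range 900 nM to 7000 nM, which means a step of a 1.6-fold higher number from compound 1 to compound 3 (0.19 log units; within the scatter).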

Compound 3, inhibition constant: 630 nM
Compound 3: the middle estimate sits 4.0-fold (0.60 log units) above what was measured; the whole stated range lies above it.
By their numbers in this assay, from the lowest: compound 2; then compound 3; then compound 1.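

In this assay, replacing trifluoromethyl with chloro on the aromatic carbon gives a 2.5-fold lower number from compound 1 to compound 3 (0.40 log units; beyond the scatter). This position therefore responds to the substituent, and the single chlorine atom serves at least as well here as the four heavy atoms of trifluoromethyl. Nothing measured accounts for the step.

On these data alone, whether the same change carries over to the core of compound 2 remains open. Also open, as far as these compounds go, is how a methoxy group, a nitrile or a bromo substituent would compare with chloro on this carbon.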